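A Chloro Analogue and Its Expected Cytotoxicity

The source may report more compounds than this note shows. Statements on the series, on what has been measured and on what is new or still open speak of the compounds shown alone.

Measured compounds:
- compound 1 `COc1ccc(NC(=S)Nc2nc[nH]n2)cc1`: > 100000 nM
- compound 2 `S=C(Nc1ccccc1)Nc1nc[nH]n1`: > 100000 nM

In an ADME assay on MT4 cells (Homo sapiens) for cytotoxicity, read by MTT assay, with a stated time of 96 h (on this read-out higher numbers stand for lower toxicity in this test and lower numbers for higher toxicity in this test), compound 1 gives > 100000 nM, which is a limit of the assay rather than a number. In this assay compound 2 gives > 100000 nM, again a limit. Compound 2 therefore stands only at a limit, with no number beneath it. Going by the values given here, the one measured step, a step that the two limits leave unreadable from compound 1 to compound 2, cannot be read because both of its values sit at the limit of > 100000 nM in this assay, at which 2 of the 2 values shown sit.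

The unmeasured compound 3 `S=C(Nc1ccc(Cl)cc1)Nc1nc[nH]n1` differs from compound 2 by chloro in place of hydrogen on an aromatic carbon. No readable step bears on this change, so the expectation rests on where compound 2 stands. Compound 3 is therefore expected to remain at or near the limit, with an estimated 100000 nM and a range from 30000 nM to 300000 nM. The step of a number no higher from compound 2 to compound 3 (the limit leaves the size open) is expected to be none beyond the scatter.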

Compound 3, half-maximal cytotoxic concentration: 47000 nM
For compound 3 the middle estimate is 2.1-fold (0.33 log units) above the measured one, within the range that was stated.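

At this position, an aromatic carbon para to a group of 9 heavy atoms, chloro brings the read-out under the limit in this assay, with an at least 2.1-fold lower number from compound 2 to compound 3 (0.32 log units; beyond the scatter). Set against methoxy at the same place, chloro gives an at least 2.1-fold lower number from compound 1 to compound 3 (0.32 log units; beyond the scatter), whereas the step between the two earlier compounds cannot be read. Both new steps are open on one side because their starting values are limits and not numbers: the limit of > 100000 nM in this assay, at which 2 of the 3 values shown sit.

On these data alone, whether bromo, an amine or a carboxylic acid at this position would also bring the read-out under the limit remains open. As far as these compounds go, the full size of the two steps also remains open, as does whether a longer chain in place of chloro would give a number near that of compound 3.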